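N-Demethylation of the Pyrazole Amide: An Expected Flat Step

The source may hold more compounds than are shown below. What is called first, only, known or untested is meant among the compounds shown, and "the series" means these compounds.

Going by the values given here, compound 2 `CNC(=O)N1CCCc2ccc(NC(=O)c3ccc(-c4cnn(C)c4)cc3)cc21` gives 730 nM in a functional assay on MV4-11 cells (Homo sapiens) for antiproliferative activity, with a stated time of 6 days (a lower number here means a stronger inhibitor, a higher number a weaker inhibitor), the higher of the two numbers known, within the scatter of compound 1 `CNC(=O)N1CCCc2ccc(NC(=O)c3ccc(-c4cc[nH]n4)cc3)cc21`, which gives 550 nM. Among the compounds with values here, the one measured step, a 1.3-fold higher number from compound 1 to compound 2 (0.12 log units; within the scatter), involved a different 1H-pyrazol-3-yl and was flat. Compound 3 `CNC(=O)N1CCCc2ccc(NC(=O)c3ccc(-c4cn[nH]c4)cc3)cc21` differs from compound 2 by hydrogen in place of methyl on an aromatic nitrogen, that is 1-methyl-1H-pyrazol-4-yl to 1H-pyrazol-4-yl. Within the data shown here, with only that flat step to go on, no change beyond the scatter is expected, a 1.2-fold lower number from compound 2 to compound 3 (0.09 log units; within the scatter). Compound 3 is therefore estimated at 600 nM, between 250 nM and 1500 nM.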

Compound 3, half-maximal inhibitory concentration: 870 nM
Compound 3: the middle estimate sits 1.5-fold (0.16 log units) below what was measured, within the range that was stated.
By their numbers in this assay, from the lowest: compounds 1, 2 and 3 (each within the scatter of the next).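

Replacing the methyl on the aromatic nitrogen with hydrogen leaves the number within the scatter (a 1.2-fold higher number from compound 2 to compound 3 (0.08 log units; within the scatter)), so methyl and hydrogen cannot be told apart at this nitrogen. Going from 1H-pyrazol-3-yl to 1H-pyrazol-4-yl is equally flat (a 1.6-fold higher number from compound 1 to compound 3 (0.20 log units; within the scatter)), so these two unmethylated pyrazoles cannot be told apart either. No evidence at hand accounts for these flat steps. The compounds shown leave open whether a longer chain or an amine on that nitrogen, or a carboxylic acid in place of the pyrazole, would move the number beyond the scatter.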